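Loss of one chloro on the shared core: paired analogues

The source may hold more compounds than are shown below. What is called first, only, known or untested is meant among the compounds shown, and "the series" means these compounds.

Three benzyl-substituted analogues have been run in a functional assay on PC-3 cells (Homo sapiens) for cytotoxicity, read by sulforhodamine B assay, with a stated time of 48 h; on this read-out lower numbers stand for stronger inhibition of growth and higher numbers for weaker inhibition of growth. Compound 3 `ClCc1cccc(Cn2cnc3nc(Cl)nc(Cl)c32)c1` gives 2880 nM. Compound 1 `ClCc1cccc(Cn2cnc3ncnc(Cl)c32)c1`, which carries hydrogen in place of chloro on an aromatic carbon, gives 5370 nM; the step of a 1.9-fold higher number from compound 3 to compound 1 (0.27 log units; within the scatter) is small. Compound 2 `ClCc1ccc(Cn2cnc3nc(Cl)nc(Cl)c32)cc1` gives 37200 nM, the highest number of the three; against compound 3 its number is higher by a margin that lies beyond the scatter, and against compound 1 likewise. The two cores of compound 2 and compound 3 are built from the same atoms joined differently, and the difference between them is not broken down here.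

Compound 4 `ClCc1ccc(Cn2cnc3ncnc(Cl)c32)cc1` is not yet measured. It stands to compound 2 as compound 1 stands to compound 3: hydrogen in place of chloro on an aromatic carbon, the same change at the same kind of place, both descriptions matching word for word. Since the earlier step of a 1.9-fold higher number from compound 3 to compound 1 (0.27 log units; within the scatter) stayed within the scatter, the step from compound 2 to compound 4 is expected to be of like size, a 1.5-fold higher number from compound 2 to compound 4 (0.17 log units; within the scatter), resting on that single precedent and on the value of compound 2 37200 nM. Compound 4 is therefore estimated at 55000 nM in this assay, with a range from 20000 nM to 150000 nM.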

Compound 4, concentration for total growth inhibition: 2950 nM
Compound 4: middle estimate off by 19-fold (1.27 log units), on the high side, outside the stated range (below it).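

Hydrogen in place of chloro, at the ring carbon between two ring nitrogen atoms, is a large step on one of the two cores in this series: a 13-fold lower number from compound 2 to compound 4 (1.10 log units; beyond the scatter). This change therefore cannot be carried as a fixed step from one core to the other in this assay: the same change on two cores in this assay, a 1.9-fold higher number (0.27 log units; within the scatter) from compound 3 to compound 1 and a 13-fold lower number (1.10 log units; beyond the scatter) from compound 2 to compound 4, 24-fold (1.37 log units) apart, beyond the scatter of two such steps

The two pairs show that the size of the step differs with the core, but they do not show what in the cores sets that difference, and two pairs give no rule for any further core.

The compounds shown leave open whether another group at that same carbon, such as an amine or a methoxy group, would also give steps that differ between the two cores. Also open, on these data alone, is how either core would respond if the remaining chloro group gave way to an amine.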